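A few compounds are considered here, and "the series" means these few. Any claim that something is new, unique, unknown or untested is made for them only; others in the source may bear on it.

Of the compounds shown here, three have been measured in a functional assay on MCF7 cells (Homo sapiens) for antiproliferative activity, read by MTT assay, with a stated time of 72 h; a higher number here means a weaker inhibitor, a lower number a stronger inhibitor. Compound 2 `C=C(Br)C(=O)Nc1ccc2c(c1)/C(=C\c1ccsc1)C(=O)N2` gives 2100 nM. Compound 1 `C=C(Br)C(=O)Nc1ccc2c(c1)/C(=C\c1ccc(C)s1)C(=O)N2` gives 4400 nM. Compound 3 `C=C(Br)C(=O)Nc1ccc2c(c1)/C(=C/c1ccsc1)C(=O)N2` gives 2800 nM.

Two single changes link these compounds. Going from compound 2 to compound 1 the change is 5-methylthiophen-2-yl in place of thiophen-3-yl on a double-bonded chain carbon bound to a double-bonded ring carbon and it made a step of a 2.1-fold higher number from compound 2 to compound 1 (0.32 log units; beyond the scatter). Going from compound 2 to compound 3 the change is the two compounds have the same atoms and bonds and differ only in configuration as drawn: 1 of 1 stereo elements differ; a double bond is drawn E in compound 2 and Z in compound 3 and the step was a 1.3-fold higher number from compound 2 to compound 3 (0.12 log units; within the scatter); the two compounds share (the fact that compounds 2 and 3 differ only in the configuration as drawn).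

Compound 4 `C=C(Br)C(=O)Nc1ccc2c(c1)/C(=C/c1ccc(C)s1)C(=O)N2` has not yet been measured. From compound 3 to compound 4 the change is 5-methylthiophen-2-yl in place of thiophen-3-yl on a double-bonded chain carbon bound to a double-bonded ring carbon. This is the same change that was already made from compound 2 to compound 1, and the cores of compound 3 and compound 2 differ only as described by the two compounds have the same atoms and bonds and differ only in configuration as drawn: 1 of 1 stereo elements differ; a double bond is drawn E in compound 2 and Z in compound 3. The expectation therefore rests on compound 1, with its value of 4400 nM, and the step it showed: the step from compound 3 to compound 4 is expected to be a 2.0-fold higher number from compound 3 to compound 4 (0.29 log units; within the scatter) in this assay. Compound 4 is accordingly estimated at 5500 nM, with a likely range from 2800 nM to 11000 nM.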

Compound 4, half-maximal inhibitory concentration: 3000 nM
The estimate for compound 4 lay 1.8-fold (0.26 log units) above the measured number, and the stated range covers the measured number.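

In this assay, putting 5-methylthiophen-2-yl in place of thiophen-3-yl gives a 1.1-fold higher number from compound 3 to compound 4 (0.03 log units; within the scatter), and the two steps made by this same change can be set side by side: the same change on two cores in this assay, a 2.1-fold higher number (0.32 log units; beyond the scatter) from compound 2 to compound 1 and a 1.1-fold higher number (0.03 log units; within the scatter) from compound 3 to compound 4, 2.0-fold (0.29 log units) apart, within the scatter of two such steps. The two cores therefore give no sign that the change behaves differently on one than on the other, but two pairs cannot establish a fixed size for the step, as only the first step lies beyond the scatter. Between the two double-bond forms carrying 5-methylthiophen-2-yl stands a 1.5-fold lower number from compound 1 to compound 4 (0.17 log units; within the scatter), so the drawn configuration produces no step beyond the scatter in this pair.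

On these data alone, it remains open whether the same agreement would hold for other groups on the double-bonded chain carbon, such as a phenyl ring or a furan-2-yl ring. As far as these compounds go, it is also open whether it would hold on a third core, or for a thiophene carrying a carboxylic acid or an amine.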